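The compounds below may be only part of what the source reports. "The series", "measured", "known", "first", "only" and "open" are said of these compounds alone.

Compound 3 `CC(C)C(CC(N)=O)c1ccc(-c2ccc3cccc(F)c3c2)[nH]c1=O` is the reference point. In an assay on CHO cells for displacement of a labelled ligand from prostaglandin E2 receptor EP3 subtype (Homo sapiens), read by radioligand binding (on this read-out higher numbers stand for weaker inhibition and lower numbers for stronger inhibition), compound 3 gives 5 nM, the lowest of the three numbers in hand. Compound 1 `CC(C)C(Nc1nnc[nH]1)c1ccc(-c2ccc3cccc(F)c3c2)[nH]c1=O` gives 22 nM in this assay, and compound 2 `CC(C)C(Cc1nnn[nH]1)c1ccc(-c2ccc3cccc(F)c3c2)[nH]c1=O` gives 34 nM. Exchanging the triazolylamino group for the carbamoylmethyl group gave a 4.4-fold lower number from compound 1 to compound 3 (0.64 log units; beyond the scatter), and exchanging the tetrazolylmethyl group for it gave a 6.8-fold lower number from compound 2 to compound 3 (0.83 log units; beyond the scatter), so in this series the open-chain amide sits clearly below either heterocycle; between the two heterocycles themselves the step was only a 1.5-fold higher number from compound 1 to compound 2 (0.19 log units; within the scatter).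

Compound 4 `Cc1c[nH]c(C(c2ccc(-c3ccc4cccc(F)c4c3)[nH]c2=O)C(C)C)n1` is the next compound in line. The change is 4-methyl-1H-imidazol-2-yl in place of carbamoylmethyl on a saturated chain carbon bound to an aromatic carbon and a saturated chain carbon. Both measured steps bear on it: in each, a five-membered aromatic ring stood where the carbamoylmethyl group now stands, or close along the same chain, and in each case the number came out beyond the scatter above that of compound 3. Read from compound 3, the new imidazolyl ring is expected to move the number back upward by about a 4.0-fold higher number from compound 3 to compound 4 (0.60 log units; beyond the scatter). The estimate for compound 4 is 20 nM, with a range from 7 nM to 60 nM, pending the measurement.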

Compound 4, inhibition constant: 12 nM
Beside the measured number, compound 4's estimate is 1.7-fold (0.22 log units) above it; low and high end bracket the measured number.
By their numbers in this assay, from the lowest: compound 3; then compounds 4, 1 and 2 (each within the scatter of the next, the first and the last beyond it).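

In this assay, a five-membered aromatic ring bound straight to the saturated chain carbon still does not match the carbamoylmethyl group, with a 2.4-fold higher number from compound 3 to compound 4 (0.38 log units; beyond the scatter), so compound 3 now holds the lowest number against all three ring-bearing groups. The same ring does improve on one earlier heterocycle, with a 2.8-fold lower number from compound 2 to compound 4 (0.45 log units; beyond the scatter), which shows that a ring at this place need not read as high as the tetrazole does, whereas a 1.8-fold lower number from compound 1 to compound 4 (0.26 log units; within the scatter) is within the scatter, so that pair cannot be ranked. No measurement in hand explains any of these differences.

The three ring-bearing groups differ from one another at once in the ring, in what joins it to the chain carbon and in the methyl group, so the contribution of that methyl cannot be separated out, and the unsubstituted 1H-imidazol-2-yl group would be the direct test. Also open, as far as these compounds go, is how a plain amine, a carboxylic acid or a longer chain ending in the carbamoyl group would read on this same chain carbon.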